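Carrying One Small Swap From One Core to Another

The compounds below may be only part of what the source reports. "The series", "measured", "known", "first", "only" and "open" are said of these compounds alone.

Compound 1 `O=C(COc1c(-c2ccccc2)oc2ccccc2c1=O)Nc1ccc(F)cc1` and compound 2 `COc1ccc(NC(=O)COc2c(-c3ccccc3)oc3ccccc3c2=O)cc1` share a core and differ only on the outer aromatic ring. In a functional assay on NPC-TW01 cells (Homo sapiens) for antiproliferative activity, read by MTT assay, with a stated time of 72 h (on this read-out higher numbers stand for weaker inhibition of growth and lower numbers for stronger inhibition of growth), compound 1 gives 9500 nM, and compound 2 gives 5480 nM; the change methoxy in place of fluoro on an aromatic carbon made a step of a 1.7-fold lower number from compound 1 to compound 2 (0.24 log units; within the scatter). Compound 3 `O=C(COc1ccc2oc(-c3ccccc3)cc(=O)c2c1)Nc1ccc(F)cc1` has the same atoms as compound 1 joined differently; the difference between the two cores is not broken down here. In this assay compound 3 gives 740 nM, the lowest of the three numbers. Compound 4 `COc1ccc(NC(=O)COc2ccc3oc(-c4ccccc4)cc(=O)c3c2)cc1` is compound 3 carrying the same change, (methoxy in place of fluoro on an aromatic carbon), at the same place. The earlier step of a 1.7-fold lower number from compound 1 to compound 2 (0.24 log units; within the scatter) was small, so the step expected for compound 4 is of similar size, a 1.5-fold lower number from compound 3 to compound 4 (0.17 log units; within the scatter). Compound 4 is therefore estimated at 500 nM, likely between 200 nM and 1500 nM.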

Compound 4, concentration for 50% growth inhibition: 710 nM
Beside the measured number, compound 4's estimate is 1.4-fold (0.15 log units) below it, and the stated range covers the measured number.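

On the core of compound 3, methoxy in place of fluoro gives a 1.0-fold lower number from compound 3 to compound 4 (0.02 log units; within the scatter) in this assay, so here too the swap stays within the usual scatter. Set side by side, the two steps agree: the same change on two cores in this assay, a 1.7-fold lower number (0.24 log units; within the scatter) from compound 1 to compound 2 and a 1.0-fold lower number (0.02 log units; within the scatter) from compound 3 to compound 4, 1.7-fold (0.22 log units) apart, within the scatter of two such steps. This shows that the swap made no readable difference on either core, but neither step stands clear of the scatter, so it does not show a real effect carrying over from one core to the other.

The compounds shown leave open how an amine, a carboxylic acid or a nitrile in this place would behave on the two cores. They also leave open whether a step clearly larger than the scatter on one core would hold on the other.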